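This account rests on a few compounds, and the source may have more. Where it says the series, first, only, none or still open, it means among the compounds named here.

Measured compounds in a functional assay on NCI-H460 cells (Homo sapiens) for cytotoxicity, read by sulforhodamine B assay, with a stated time of 48 h, tested at 1 uM; a lower number here means a stronger effect, a higher number a weaker effect of the compound at the concentration tested:
- compound 1, `COc1cc(-c2cc(/C=C/C(=O)c3ccc(Cl)c(Cl)c3)[nH]n2)cc(OC)c1OC`: 93%
- compound 2, `COc1ccc(-c2cc(/C=C/C(=O)c3ccc(N)cc3)[nH]n2)cc1OC`: 94%
- compound 3, `COc1ccc(-c2cc(/C=C/C(=O)c3cc(OC)c(OC)c(OC)c3)[nH]n2)cc1OC`: 52%

Among these three numbers, compound 1 stands second highest. Its nearest neighbour is compound 2, whose value lies within the usual scatter of it, so the two cannot be told apart. Its furthest neighbour is compound 3, whose lower number lies beyond the scatter and therefore shows a clearly stronger effect at the tested concentration.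

The unmeasured compound 4, `COc1ccc(C(=O)/C=C/c2cc(-c3cc(OC)c(OC)c(OC)c3)n[nH]2)cc1OC`, keeps the shared core of compound 1 and differs in one place: 3,4-dimethoxyphenyl in place of 3,4-dichlorophenyl on a carbonyl carbon. Among the measured compounds shown here, no measured pair shows this very change, so its size is unknown. Still, compound 3, which carries methoxy groups on both outer rings, gives 52%, far below compound 1. This makes a downward step, towards a stronger effect, the more likely outcome for compound 4, though it may also stay within the scatter of compound 1. Compound 4 is therefore expected to give 75%, with a range from 50% to 95%, an estimated step of a number 18 percentage points lower from compound 1 to compound 4 (beyond the scatter).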

Compound 4, a percentage reported as activity, at one concentration (the size of the read-out at that concentration, not a potency): 70%
The estimate for compound 4 lay 5 percentage points above the measured number, within the range that was stated.
By their numbers in this assay, from the lowest: compound 3; then compound 4; then compounds 1 and 2 (each within the scatter of the next).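

In this assay the change to 3,4-dimethoxyphenyl in place of 3,4-dichlorophenyl on a carbonyl carbon gives a number 23 percentage points lower from compound 1 to compound 4 (beyond the scatter) and so a clearly stronger effect at the tested concentration. Among the compounds shown here, this is the first change in a single place that can be read directly, and it shows that the group on this carbonyl carbon matters on the shared core of compound 1. Nothing measured here explains the step.

A single step cannot show whether the methoxy groups or the loss of the chlorines account for the result, and a plain phenyl ring or a phenyl carrying one methoxy group at this place would help separate the two. From the compounds shown here alone, whether the step holds at other concentrations also remains open, as a single concentration gives the size of the effect and not a potency.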